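Moving the methyl on the phenoxy ring: compound 2 to compound 3

The source may report more compounds than this note shows. Statements on the series, on what has been measured and on what is new or still open speak of the compounds shown alone.

Measured compounds:
Compound 1, `CN1CCN(c2nc(N)nc(COc3ccccc3)n2)CC1`, 507 nM
Compound 2, `Cc1ccccc1OCc1nc(N)nc(N2CCN(C)CC2)n1`, 87 nM

Both compounds were tested in an assay on HEK293 cells for displacement of a labelled ligand from 5-hydroxytryptamine receptor 6 (Homo sapiens), read by radioligand binding, with a stated time of 1 h; on this read-out higher numbers stand for weaker inhibition and lower numbers for stronger inhibition. Compound 1 gives 507 nM in this assay. Going by the values given here, compound 2 gives 87 nM, the lowest of the two numbers; the only other compound, compound 1, stands at a higher number, and the step of a 5.8-fold lower number from compound 1 to compound 2 (0.77 log units; beyond the scatter), which came with methyl in place of hydrogen on an aromatic carbon, lies beyond the scatter.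

Compound 3, `Cc1cccc(OCc2nc(N)nc(N3CCN(C)CC3)n2)c1`, has not yet been measured. It differs from compound 2 by 3-methylphenyl in place of 2-methylphenyl on an oxygen on a saturated carbon. Among the compounds with values here, no measured step moves the methyl from one aromatic carbon to another; the one step on record, from compound 1 to compound 2, only shows that adding the methyl to the phenoxy ring lowered the number. With nothing directly comparable, compound 3 is expected to stay close to compound 2, with the step of a 1.5-fold higher number from compound 2 to compound 3 (0.17 log units; within the scatter) estimated to fall within the scatter. The value for compound 3 is therefore estimated at 130 nM, within a range from 40 nM to 450 nM.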

Compound 3, inhibition constant: 207 nM
For compound 3 the middle estimate is 1.6-fold (0.20 log units) below the measured one, within the range that was stated.
By their numbers in this assay, from the lowest: compound 2; then compound 3; then compound 1.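

Exchanging 2-methylphenyl for 3-methylphenyl in this assay gives a 2.4-fold higher number from compound 2 to compound 3 (0.38 log units; beyond the scatter) even though the atoms stay the same, so the place of the methyl on the phenoxy ring matters as well as its presence. The 3-methylphenyl group nevertheless keeps a gain over the unsubstituted phenyl of the parent, with a 2.4-fold lower number from compound 1 to compound 3 (0.39 log units; beyond the scatter) on this read-out, so the lower number seen on adding a methyl is not confined to the 2-methylphenyl compound. No supporting evidence bears on why the two placements differ.

From the compounds shown here alone, the order rests on a single pair of methyl isomers, so it remains open whether 4-methylphenyl would continue the trend or whether a different group would favour the same place, as 2-chlorophenyl over 3-chlorophenyl or 2-methoxyphenyl over 3-methoxyphenyl. Going by these compounds, it is also open whether the preference for 2-methylphenyl would survive a change elsewhere in the molecule, such as an ethyl group in place of the methyl on the piperazine nitrogen or a longer chain joining the oxygen to the shared core.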